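The compounds below may be only part of what the source reports. "The series", "measured", "known", "first", "only" and "open" are said of these compounds alone.

In an assay on cells for displacement of a labelled ligand from adenosine receptor A3 (Homo sapiens), read by scintillation counting and radioligand binding, with a stated time of 180 min, tested at 10 uM (on this read-out lower numbers stand for less inhibition and higher numbers for more inhibition at the one concentration tested (going by the name of the read-out)), three compounds have been measured so far. Compound 1 `CN1CCN(c2nc(-c3ccc(Cl)c(Cl)c3)nc3[nH]cnc23)CC1` reaches a value that is a limit of the assay, namely > 80%. Compound 3 `CN1CCN(c2nc(-c3ccc(Cl)c(C(F)(F)F)c3)nc3[nH]cnc23)CC1` also reaches a limit, > 80%. The step that the two limits leave unreadable from compound 1 to compound 3 cannot be read, because both of its ends sit at the limit of > 80% in this assay, at which 2 of the 3 values shown sit. Going by the values given here, compound 2 `Cn1cnc2c(N3CCCCC3)nc(-c3cccc(O)c3O)nc21` is the only one with a plain number: in this assay compound 2 gives 33.7%, which leaves it as the sole fixed point for what follows.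

Compound 4 `Cn1cnc2c(N3CCCCC3)nc(-c3cccc(O)c3)nc21` has not been measured yet. It differs from compound 2 in one place: hydrogen in place of hydroxy on an aromatic carbon. Among the compounds with values here, no measured step touches this kind of change, and the single measured step is unreadable, so there is nothing to set a size or direction for it. On that basis the step of a number 5.7 percentage points lower from compound 2 to compound 4 (within the scatter) is expected to stay within the usual scatter, with no sure direction. Compound 4 is therefore estimated at 28%, within a range from 8% to 50%.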

Compound 4, a percentage reported as inhibition, at one concentration (the size of the read-out at that concentration, not a potency): 49.1%
Beside the measured number, compound 4's estimate is 21.1 percentage points below it; the measured number falls inside the stated range.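

In this assay, going by these compounds alone, this is the first step that can be read, and it concerns a different part of the molecule from the earlier unreadable step: going from 2,3-dihydroxyphenyl to 3-hydroxyphenyl gives a number 15.4 percentage points higher from compound 2 to compound 4 (beyond the scatter). At this place, on an aromatic carbon ortho to a hydroxy group and ortho to a large group, the hydroxy group is therefore not required for inhibition at the one concentration tested, and hydrogen gives a reading higher by more than the usual scatter. Nothing measured here gives a reason for the size or direction of this step.

From the compounds shown here alone, whether a methoxy group or an amine at the same place would give a higher or lower reading than hydrogen stays open, as does the effect of replacing the remaining hydroxy group with hydrogen. Going by these compounds, whether the same change would shift the reading in the same direction on the core of compound 1 is also open.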